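Phenoxy for Phenyl on a Shared Core

The source may report more compounds than this note shows. Statements on the series, on what has been measured and on what is new or still open speak of the compounds shown alone.

Of the compounds shown here, two have been tested in a functional assay on the whole organism (strain Wistar) for inhibition, with Rattus norvegicus as the target, read by paw edema, with stated times of 30 min and 2 h, at a dose of 20 mg/kg by the oral route; on this read-out lower numbers stand for less inhibition and higher numbers for more inhibition at the one dose given (going by the name of the read-out). Compound 1 `O=C(NCc1nn2c(Cc3ccccc3)nnc2s1)c1ccccc1` gives 21.2%, and compound 2 `c1ccc(Cc2nnc3sc(Cc4cc5ccccc5[nH]4)nn23)cc1` gives 36.7%, the higher of the two numbers, with a gap to compound 1 that lies beyond the scatter. Compound 3 `c1ccc(OCc2nnc3sc(Cc4cc5ccccc5[nH]4)nn23)cc1` differs from compound 2 in one place: phenoxy in place of phenyl on a saturated chain carbon bound to an aromatic carbon. Among the compounds with values here, no measured pair shows this change, so its effect is open. Only a small step is expected, a number 2.7 percentage points lower from compound 2 to compound 3 (within the scatter), not clearly beyond the scatter in either direction. Compound 3 is therefore expected to give 34%, with a range from 20% to 48%.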

Compound 3, a percentage reported as inhibition, in the whole organism at one dose (the size of the read-out at that dose, not a potency): 32.1%
Estimate against measurement, compound 3: 1.9 percentage points above, within the range that was stated.
By their numbers in this assay, from the lowest: compound 1; then compounds 3 and 2 (each within the scatter of the next).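

In this assay, the step for phenoxy in place of phenyl on a saturated chain carbon bound to an aromatic carbon is a number 4.6 percentage points lower from compound 2 to compound 3 (within the scatter). This position therefore accepts one added oxygen, counted as a hydrogen-bond acceptor, with the two numbers staying within the scatter. Nothing available explains this result.

As far as these compounds go, whether an amine or a carboxylic acid at this place would also stay within the scatter remains open. So does whether this change would read the same on the core of compound 1.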